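Benzyl exchange on the hindered phenol amide series

This account rests on a few compounds, and the source may have more. Where it says the series, first, only, none or still open, it means among the compounds named here.

Values come from a functional assay, read by spectrophotometry, with a stated time of 30 min (a lower number here means a stronger inhibitor, a higher number a weaker inhibitor), and are read as half-maximal inhibitory concentrations.
- compound 1 `O=C(/C=C/c1ccccc1)NCCC1CCN(Cc2ccccc2)CC1` gives > 200000 nM as a limit of the assay, not a number
- compound 2 `CC(C)(C)c1cc(CCC(=O)NCCC2CCN(Cc3ccccc3)CC2)cc(C(C)(C)C)c1O` gives 54500 nM
- compound 3 `CC(C)(C)c1cc(/C=C/C(=O)NCCC2CCN(Cc3cccc(F)c3)CC2)cc(C(C)(C)C)c1O` gives 55200 nM

Among the measured compounds shown here, only two compounds have numbers, and compound 3 (55200 nM) and compound 2 (54500 nM) lie within the scatter of each other. Compound 1 carries only a limit, so it gives no number to set beside them.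

The next compound to be measured is compound 4 `CC(C)(C)c1cc(/C=C/C(=O)NCCC2CCN(Cc3ccc(Br)cc3)CC2)cc(C(C)(C)C)c1O`. It differs from compound 3 by 4-bromophenyl in place of 3-fluorophenyl on a saturated chain carbon bound to an amine nitrogen in a ring. For the measured compounds named here, no measured pair shows a change at this place, so the expectation rests on compound 3 (55200 nM) and the range is kept wide. In this assay no step beyond the scatter is expected (a 1.1-fold lower number from compound 3 to compound 4 (0.04 log units; within the scatter)). Compound 4 is estimated at 50000 nM with an expected range (15000 nM to 160000 nM).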

Compound 4, half-maximal inhibitory concentration: 85600 nM
Compound 4: middle estimate off by 1.7-fold (0.23 log units), on the low side; measured number inside the range.
By their numbers in this assay, from the lowest: compounds 2, 3 and 4 (each within the scatter of the next). At a limit, above all of these: compound 1.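

In this assay, this is the only pair shown that differs at this place: 4-bromophenyl in place of 3-fluorophenyl on a saturated chain carbon bound to an amine nitrogen in a ring gives a 1.6-fold higher number from compound 3 to compound 4 (0.19 log units; within the scatter). The exchange of both the halogen and its ring position therefore produces no step beyond the scatter, although this single pair cannot separate the two parts of the change. Nothing shown here gives a cause for this step.

Going by these compounds, whether a phenyl ring carrying a methoxy group, a carboxylic acid or an amine at this place would give a step beyond the scatter remains open. So does whether any exchange at this place can bring the number far below those of the compounds shown.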